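Series notes: chloro-to-amino swap on the fused ring

The source may hold more compounds than are shown below. What is called first, only, known or untested is meant among the compounds shown, and "the series" means these compounds.

Measured so far in a functional assay on HCT-15 cells (Homo sapiens) for antiproliferative activity, read by sulforhodamine B assay, with a stated time of 48 h; a lower number here means a stronger inhibitor of growth, a higher number a weaker inhibitor of growth:
- compound 1, `Nc1nn(C(=O)Nc2ccc(Cc3ccccc3)cc2)c2ccccc12`: 1080 nM
- compound 2, `Nc1nn(C(=O)Nc2ccc(Cc3ccccc3)cc2)c2ccc(Cl)cc12`: 45.8 nM

Within the data shown here, compound 2 stands lowest of the two numbers; the only neighbour is compound 1, and the step of a 24-fold lower number from compound 1 to compound 2 (1.37 log units; beyond the scatter) is the single change documented. It shows that a substituent at this ring carbon can shift the read-out substantially.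

The unmeasured compound 3, `Nc1ccc2c(c1)c(N)nn2C(=O)Nc1ccc(Cc2ccccc2)cc1`, differs from compound 2 by amino in place of chloro on an aromatic carbon. Among the measured compounds shown here, no measured step covers an amino at this carbon, so the one step available, a 24-fold lower number from compound 1 to compound 2 (1.37 log units; beyond the scatter), bears on it only indirectly: it tells how far the chloro moved the number from the unsubstituted compound 1, not what a different group does in its place. With the chloro gone, the gain it brought cannot be assumed to carry over, and the number is expected to move back toward that of compound 1 rather than stay at the level of compound 2. The expected step is therefore an 8.7-fold higher number from compound 2 to compound 3 (0.94 log units; beyond the scatter), with wide uncertainty. For compound 3 in this assay the estimate is 400 nM, within a range of 100 nM to 1500 nM.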

Compound 3, concentration for 50% growth inhibition: 2750 nM
Beside the measured number, compound 3's estimate is 6.9-fold (0.84 log units) below it; measured number outside the range, above it.
By their numbers in this assay, from the lowest: compound 2; then compound 1; then compound 3.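

Replacing chloro with amino on this aromatic carbon gives, in this assay, a 60-fold higher number from compound 2 to compound 3 (1.78 log units; beyond the scatter), so the low number of compound 2 does not survive a change of this one atom, and the carbon tolerates less freedom of substitution than the first step alone could show. Amino also fails to return the series to the unsubstituted level, with a 2.5-fold higher number from compound 1 to compound 3 (0.41 log units; beyond the scatter): this is a modest step but beyond the scatter, and it runs opposite in direction to a 24-fold lower number from compound 1 to compound 2 (1.37 log units; beyond the scatter), so at this carbon the outcome depends on which group is present, not merely on whether a group is present. No measured evidence accounts for the gap between the chloro and amino compounds.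

The compounds shown leave open whether the low number belongs to chloro alone or extends to fluoro, bromo or methyl on the same carbon. They also leave open whether a methoxy group or an acetylated amino group would sit with compound 2 or with compound 3 in this assay, and so how far the series can be moved from here.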